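Cytotoxicity notes: amide variation on the shared core

The source may hold more compounds than are shown below. What is called first, only, known or untested is meant among the compounds shown, and "the series" means these compounds.

Measured compounds:
- compound 1, `O=C(c1ccc(NCc2cncn2Cc2ccc(-c3ccccc3)cc2)cc1-c1ccccc1)N1CCCCC1`, > 1000 nM in a toxicity assay on NIH3T3 cells (Mus musculus) for cytotoxicity, read by resazurin assay; on this read-out lower numbers stand for an effect already at smaller amounts and higher numbers for an effect only at larger amounts of compound
- compound 2, `COC(=O)c1ccc(NCc2cncn2Cc2ccccc2Cl)cc1-c1ccccc1`, 10000 nM
- compound 3, `CCc1ccc(Cn2cncc2CNc2ccc(-c3nc4ccccc4s3)c(-c3ccccc3)c2)cc1`, > 1000 nM

The value of compound 1 is a limit of this assay, not a number. The value of compound 3 is likewise a limit. Within the data shown here, compound 2 is the only one with a numeric reading, 10000 nM. Among the measured compounds shown here, compound 1 therefore stands at the limit of > 1000 nM in this assay, at which 2 of the 3 values shown sit, and no step between measured compounds is known.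

Compound 4, `CN(C)C(=O)c1ccc(NCc2cncn2Cc2ccc(-c3ccccc3)cc2)cc1-c1ccccc1`, carries dimethylamino in place of piperidin-1-yl on a carbonyl carbon. Compound 4 is expected to keep the limit behaviour of compound 1, so the estimated step that the limit leaves unreadable from compound 1 to compound 4 is none beyond the scatter. For compound 4 the estimate in this assay is 5000 nM, ranging from 1500 nM to 30000 nM.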

Compound 4, half-maximal effective concentration: > 1000 nM
Compound 4 was reported as a limit; the forecaster's own chance of this, stated with the estimate: 60%; the middle value does not contradict the limit.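

Compound 1 and compound 4 both stand as limits in this assay, not as numbers, and the step between them cannot be read. The compounds shown leave open where the values of these two compounds lie beyond their limits.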